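Following the sulfonyl swap from compound 2 to compound 3

This account rests on a few compounds, and the source may have more. Where it says the series, first, only, none or still open, it means among the compounds named here.

Measured in a physicochemical assay for solubility, read by chemiluminescence, measured as kinetic solubility; on this read-out higher numbers stand for higher solubility and lower numbers for lower solubility:
compound 1 (`CC(=O)NCc1cccc(Cn2nc(NS(=O)(=O)c3ccc(Cl)s3)c3c(C(C)O)cccc32)c1`): >= 208 ug/mL (a limit of the assay, not a number)
compound 2 (`COc1cccc2c1c(NS(=O)(=O)c1ccc(Cl)c(Cl)c1)nn2Cc1cccc(CNC(=O)C(C)(C)O)c1`): 76 ug/mL

Going by the values given here, only two compounds have been measured so far, and they differ in more than one place. Among the compounds with values here, compound 2, at 76 ug/mL, holds the only true number in the set. Within the data shown here, the other result is a limit, so compound 2 can be placed against it only loosely, and no measured step isolates a single change.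

Compound 3 (`COc1cccc2c1c(NS(=O)(=O)c1ccc(C)c(F)c1)nn2Cc1cccc(CNC(=O)C(C)(C)O)c1`) keeps the rest of compound 2 and carries 3-fluoro-4-methylphenyl in place of 3,4-dichlorophenyl on a sulfonyl sulfur. Neither group carries a net charge, and each is one six-membered aromatic ring of carbon only.

Among the measured compounds shown here, with no measured step to size this swap, no shift beyond the usual scatter is expected in this assay, and no firm direction can be given. The estimated change is a 1.1-fold higher number from compound 2 to compound 3 (0.05 log units; within the scatter), which rests on the value of compound 2 at 76 ug/mL. The expected value for compound 3 is 85 ug/mL, with an estimated range from 38 ug/mL to 185 ug/mL.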

Compound 3, solubility: 36 ug/mL
Estimate against measurement, compound 3: 2.4-fold (0.37 log units) above, outside the stated range (below it).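

Going by these compounds alone, the first change in a single place that can be read in this assay is a 2.1-fold lower number from compound 2 to compound 3 (0.32 log units; beyond the scatter), with 3-fluoro-4-methylphenyl in place of 3,4-dichlorophenyl on a sulfonyl sulfur. This shows that the group at this position can move the read-out beyond the usual scatter, even though both groups are one six-membered aromatic ring of carbon only, with the same heavy-atom count, no hydrogen-bond donors or acceptors and no net charge. Nothing shown here bears on what lies behind this step.

The compounds shown leave open which part of the swap carries the step, as the fluorine, the methyl and the loss of both chlorines are changed together, and a ring with only one of these changes, such as 4-methylphenyl, would separate them. Also open, from the compounds shown here alone, is how a ring on this sulfur carrying an amine or a carboxylic acid would read in this assay, and whether the step would hold elsewhere, as compound 1 differs from compound 2 and compound 3 in more than one place.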